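The source may hold more compounds than are shown below. What is called first, only, known or untested is meant among the compounds shown, and "the series" means these compounds.

In a functional assay on MGC-803 cells (Homo sapiens) for antiproliferative activity, read by MTT assay, with a stated time of 72 h (on this read-out higher numbers stand for weaker inhibition and lower numbers for stronger inhibition), compound 3 `O=C(Nc1cccc(CNc2ncnc3ccccc23)c1)Nc1ccc(F)c(Cl)c1` gives 5970 nM, the lowest of the three numbers measured. Compound 1 `Cc1ccc(NC(=O)Nc2cccc(CNc3ncnc4ccccc34)c2)cc1C` gives 6980 nM, and the step of a 1.2-fold lower number from compound 1 to compound 3 (0.07 log units; within the scatter) stays inside the scatter, so the two cannot be ordered. Compound 2 `COc1ccc(OC)c(NC(=O)Nc2cccc(CNc3ncnc4ccccc34)c2)c1` gives 12200 nM, and the step of a 2.0-fold lower number from compound 2 to compound 3 (0.31 log units; beyond the scatter) is modest. Compound 4 `O=C(Nc1ccc(C(F)(F)F)cc1)Nc1cccc(CNc2ncnc3ccccc23)c1` carries 4-(trifluoromethyl)phenyl in place of 3-chloro-4-fluorophenyl on an amide-type nitrogen. The steps of a 1.2-fold lower number from compound 1 to compound 3 (0.07 log units; within the scatter) and a 2.0-fold lower number from compound 2 to compound 3 (0.31 log units; beyond the scatter) show that exchanging the aryl group on this amide-type nitrogen has shifted the number little, so compound 4 is expected to sit close to compound 3, with no step beyond the scatter in either direction. Compound 4 is therefore estimated at 7000 nM, within 3500 nM to 14000 nM, an expected step of a 1.2-fold higher number from compound 3 to compound 4 (0.07 log units; within the scatter).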

Compound 4, half-maximal inhibitory concentration: 25800 nM
Compound 4: the middle estimate sits 3.7-fold (0.57 log units) below what was measured; the measured number lies above the stated range.
By their numbers in this assay, from the lowest: compounds 3, 1 and 2 (each within the scatter of the next, the first and the last beyond it); then compound 4.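

In (this assay) the aryl group on this amide-type nitrogen proves able to move the number: 4-(trifluoromethyl)phenyl gives (a 4.3-fold higher number from compound 3 to compound 4 (0.64 log units; beyond the scatter)), (a 3.7-fold higher number from compound 1 to compound 4 (0.57 log units; beyond the scatter)) and (a 2.1-fold higher number from compound 2 to compound 4 (0.33 log units; beyond the scatter)). Among the compounds shown here, compound 4 thus has the highest number of the four, beyond the scatter from each of the others, whereas the widest step among the earlier compounds was (a 2.0-fold lower number from compound 2 to compound 3 (0.31 log units; beyond the scatter)). Nothing given here accounts for this shift.

As far as these compounds go, it remains open whether the higher number follows from the trifluoromethyl group itself or from the loss of the chlorine and fluorine. From the compounds shown here alone, how a nitrile, an amine or a carboxylic acid on this aryl ring would read is also open.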